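From 4-methylphenyl to phenyl in compound 4

This account rests on a few compounds, and the source may have more. Where it says the series, first, only, none or still open, it means among the compounds named here.

Values so far in a functional assay on thoracic aorta (Rattus norvegicus, strain Wistar), with a stated time of 15 min; on this read-out higher numbers stand for an effect only at larger amounts of compound and lower numbers for an effect already at smaller amounts:
compound 1 `CCOc1ccc(Cl)cc1C(C)NC(=O)N(C)S(=O)(=O)c1ccccc1` gives 10500 nM
compound 2 `COc1ccc(Cl)cc1C(C)NC(=O)N(C)S(=O)(=O)c1ccc(Cl)cc1` gives 20000 nM
compound 3 `COc1ccc(Cl)cc1C(C)NC(=O)N(C)S(=O)(=O)c1ccc(C)cc1` gives 13800 nM

Compound 3 lies within the usual scatter of both compound 1 and compound 2, so its place among the three numbers means little. Compound 4 `COc1ccc(Cl)cc1C(C)NC(=O)N(C)S(=O)(=O)c1ccccc1` has hydrogen in place of methyl on an aromatic carbon, para to a large group: hydrogen in place of methyl on an aromatic carbon is the whole difference. Among the measured compounds shown here, the only measured step on that carbon, methyl in place of chloro, reads a 1.4-fold lower number from compound 2 to compound 3 (0.16 log units; within the scatter) and gives no sign of a real shift. No step beyond the scatter is therefore expected in this assay here. The estimated step is a 1.1-fold lower number from compound 3 to compound 4 (0.03 log units; within the scatter) and has no clear direction. For compound 4 the estimated value is 13000 nM with 7500 nM to 22000 nM as the expected range.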

Compound 4, half-maximal effective concentration: 7200 nM
The estimate for compound 4 lay 1.8-fold (0.26 log units) above the measured number; the measured number lies below the stated range.
By their numbers in this assay, from the lowest: compounds 4, 1, 3 and 2 (each within the scatter of the next, the first and the last beyond it).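

Among the compounds shown here, on the aromatic carbon para to a large group, a 1.9-fold lower number from compound 3 to compound 4 (0.28 log units; within the scatter) is no real shift, while a 2.8-fold lower number from compound 2 to compound 4 (0.44 log units; beyond the scatter) is the first step at this position to clear the scatter, and only modestly. So among the three groups seen here, only the chloro to hydrogen change separates in this assay. At the other site, a 1.5-fold lower number from compound 1 to compound 4 (0.16 log units; within the scatter) also shows no real shift on going to hydrogen in place of methyl on a saturated chain carbon bound to an oxygen on an aromatic ring. Going by these compounds, whether an amine or a carboxylic acid on that aromatic carbon would move the number further remains open. Nothing here gives a reason for these numbers.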